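This account rests on a few compounds, and the source may have more. Where it says the series, first, only, none or still open, it means among the compounds named here.

Measured compounds:
- compound 1 `O=C(Nc1ccc2c(c1)B(O)OC2)c1ccccc1C(F)(F)F`: 4400 nM
- compound 2 `O=C(Nc1ccc2c(c1)B(O)OC2)c1ccccc1Cl`: > 100000 nM, a limit
- compound 3 `O=C(Nc1ccc2c(c1)B(O)OC2)c1ccccc1OC(F)(F)F`: > 100000 nM, a limit

For the measured compounds named here, in a functional assay on PBMC cells (Homo sapiens) for inhibition, read by HTRF, with stated times of 15 min and 24 h (a higher number here means a weaker inhibitor, a lower number a stronger inhibitor), compound 1 gives 4400 nM, the only true number among the three. Compound 4 `O=C(Nc1ccc2c(c1)B(O)OC2)c1ccc(C(F)(F)F)cc1C(F)(F)F` keeps the trifluoromethyl group of compound 1 and differs as follows: trifluoromethyl in place of hydrogen on an aromatic carbon. Going by the values given here, two measured steps bear on this only indirectly, an at least 22-fold higher number from compound 1 to compound 2 (1.35 log units; beyond the scatter) and an at least 22-fold higher number from compound 1 to compound 3 (1.35 log units; beyond the scatter). Both are large, but both replace the trifluoromethyl group that compound 4 retains, so neither tests the new place. No firm change beyond the scatter is therefore expected in this assay, though the risk lies toward a higher number. The expected step is a 1.8-fold higher number from compound 1 to compound 4 (0.26 log units; within the scatter). For compound 4 the estimated value is 8000 nM, with an expected range of 1000 nM to 60000 nM.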

Compound 4, half-maximal inhibitory concentration: 8300 nM
For compound 4 the middle estimate is 1.0-fold (0.02 log units) below the measured one; measured number inside the range.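

Trifluoromethyl in place of hydrogen, para to a large group and meta to a trifluoromethyl group, gives a 1.9-fold higher number from compound 1 to compound 4 (0.28 log units; within the scatter) in this assay. For the compounds shown here, this place therefore takes a group of 4 heavy atoms with no step beyond the scatter, whereas the earlier steps changed only the trifluoromethyl group already present in compound 1.

As far as these compounds go, whether an amine or a carboxylic acid at this place would hold the value in compound 4 remains open. The step between compound 2 and compound 3 cannot be read, as both values are limits: the limit of > 100000 nM in this assay, at which 2 of the 4 values shown sit.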